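The source may report more compounds than this note shows. Statements on the series, on what has been measured and on what is new or still open speak of the compounds shown alone.

Measured so far:
compound 1 `COc1ccc(OC)c(/C=C/c2nnc(Nc3ccc(Cl)cc3)o2)c1` — > 100000 nM
compound 2 `COc1ccc(OC)c(/C=C/C(=O)N/N=C/c2ccc(Cl)cc2)c1` — > 100000 nM

In a functional assay on CAKI-1 cells (Homo sapiens) for antiproliferative activity, read by sulforhodamine B assay, with a stated time of 48 h (a higher number here means that more compound is tolerated, a lower number that less compound is tolerated), compound 1 gives only a limit of the assay, > 100000 nM. In this assay compound 2 likewise gives only a limit, > 100000 nM. Within the data shown here, compound 2 therefore stands at the limit of > 100000 nM in this assay, at which 2 of the 2 values shown sit, so no number and no measured step is available to build on. Compound 3 `COc1ccc(OC)c(/C=C/C(=O)N/N=C/c2ccccc2)c1` differs from compound 2 by hydrogen in place of chloro on an aromatic carbon. With both known values sitting at the limit, no step beyond the scatter is expected from compound 2 to compound 3 in this assay. The estimated step that the limit leaves unreadable from compound 2 to compound 3 is accordingly flat. Compound 3 is expected to give 150000 nM, within 30000 nM to 600000 nM, most likely again reported only as a limit.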

Compound 3, concentration lethal to 50% of the cells: > 100000 nM
Compound 3 ended at the assay's limit; the forecaster's own chance of this, stated with the estimate: 80%; the middle value does not contradict the limit.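

Compound 2 and compound 3 both give only a limit in this assay, and the step from 4-chlorophenyl to phenyl cannot be read. The compounds shown leave open how they rank against one another, and which structural change would give a readable value: the limit of > 100000 nM in this assay, at which 3 of the 3 values shown sit.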